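The source may report more compounds than this note shows. Statements on the series, on what has been measured and on what is new or still open speak of the compounds shown alone.

In a functional assay on the whole organism with Rattus norvegicus as the target (on this read-out lower numbers stand for an effect already at smaller amounts and higher numbers for an effect only at larger amounts of compound), compound 1 `CCOC(=O)C(=O)Nc1nc(-c2cc(Br)no2)cs1` gives 12 mg/kg, compound 3 `CCOC(=O)C(=O)Nc1nc(-c2cc(C)no2)cs1` gives 0.2 mg/kg, and compound 2 `CCOCCOC(=O)C(=O)Nc1nc(-c2cc(OC)no2)cs1` gives 3 mg/kg. Compound 2 therefore stands second highest of the three numbers, nearest to compound 1 and furthest from compound 3. Among the compounds with values here, the one measured step, a 60-fold lower number from compound 1 to compound 3 (1.78 log units; beyond the scatter), concerns methyl in place of bromo on an aromatic carbon, a different change from the one now followed. Compound 4 `CCOCCOC(=O)C(=O)Nc1nc(-c2cc(CO)on2)cs1` differs from compound 2 by 5-(hydroxymethyl)-1,2-oxazol-3-yl in place of 3-methoxy-1,2-oxazol-5-yl on an aromatic carbon. Within the data shown here, no measured step mirrors this rearrangement, so the account expects no step beyond the scatter in this assay, while holding the estimate loosely. For compound 4 the expected value is 3 mg/kg, between 0.7 mg/kg and 12 mg/kg, an expected step of no change at the digits printed from compound 2 to compound 4 (within the scatter).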

Compound 4, dose for half-maximal effect: 1.8 mg/kg
Beside the measured number, compound 4's estimate is 1.7-fold (0.22 log units) above it, and the stated range covers the measured number.
By their numbers in this assay, from the lowest: compound 3; then compounds 4 and 2 (each within the scatter of the next); then compound 1.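

In this assay, the change from 3-methoxy-1,2-oxazol-5-yl to 5-(hydroxymethyl)-1,2-oxazol-3-yl gives a 1.7-fold lower number from compound 2 to compound 4 (0.22 log units; within the scatter), so this position tolerates a rearranged ring that adds a hydrogen-bond donor without a step beyond the scatter. The earlier step at this position showed only that replacing bromo with methyl can produce a large difference. No available evidence explains the outcome. On these data alone, the ring rearrangement and the change of substituent remain unseparated, and it is open whether an aminomethyl group or a carboxylic acid on the same ring would also stay within the scatter of compound 2.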